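The compounds below may be only part of what the source reports. "The series", "measured", "known", "first", "only" and "open" are said of these compounds alone.

In a functional assay on HCT-116 cells (Homo sapiens) for inhibition, read by MTT assay, with a stated time of 24 h, tested at 10 uM (on this read-out lower numbers stand for less inhibition of growth and higher numbers for more inhibition of growth at the one concentration tested), three compounds have been measured so far:

compound 1, `CS(=O)(=O)c1ccc(-c2cnc3[nH]cc(-c4nnc(-c5ccncc5)o4)c(=O)c3c2)cc1`: 7.83%
compound 2, `O=c1c(-c2nnc(-c3ccc(F)cc3)o2)c[nH]c2ncc(-c3cccnc3)cc12`: 19.7%
compound 3, `CS(=O)(=O)c1ccc(-c2cnc3[nH]cc(-c4nnc(-c5cccnc5)o4)c(=O)c3c2)cc1`: 14.7%

Compound 4, `O=c1c(-c2nnc(-c3ccc(F)cc3)o2)c[nH]c2ncc(-c3ccncc3)cc12`, has not yet been measured in this assay. Compound 3 and compound 1 share a core and differ in one place: pyridin-4-yl in place of pyridin-3-yl on an aromatic carbon. That change made a step of a number 6.9 percentage points lower from compound 3 to compound 1 (within the scatter). Compound 2 is built on a different core, and the difference between the two cores is not broken down here. Compound 2 and compound 4 differ by the same kind of change, (pyridin-4-yl in place of pyridin-3-yl on an aromatic carbon), but not the same: in compound 4 the new group sits on an aromatic carbon of a six-membered aromatic ring with 1 nitrogen, part of a fused or bridged system of two rings, two atoms from the ring nitrogen, meta to a fused ring, para to a fused ring, whereas in compound 1 it sits on an aromatic carbon of a five-membered aromatic ring with 2 nitrogen and 1 oxygen, next to the ring nitrogen and next to the ring oxygen. In this assay compound 2 and compound 3 lie within the scatter of each other, while compound 1 lies beyond the scatter below compound 2.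

For the measured compounds named here, since the only measured instance of this kind of change stayed within the scatter, a small step is expected for compound 4 as well, although it rests on one pair only and on a change at a different place. For compound 4 the expected step is a number 4.2 percentage points lower from compound 2 to compound 4 (within the scatter). Compound 4 is estimated at 15.5%, with a range from 5% to 26%.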

Compound 4, percent growth inhibition at one concentration: 20.5%
Beside the measured number, compound 4's estimate is 5 percentage points below it; measured number inside the range.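

In this assay, putting pyridin-4-yl in place of pyridin-3-yl on the core of compound 2 gave a number 0.8 percentage points higher from compound 2 to compound 4 (within the scatter). Set beside the earlier instance of the same change, the new step does not stand apart from it: the same change on two cores in this assay, a number 6.9 percentage points lower (within the scatter) from compound 3 to compound 1 and a number 0.8 percentage points higher (within the scatter) from compound 2 to compound 4, 7.7 percentage points apart, within the scatter of two such steps. For the compounds shown here, on both cores, then, the change stayed within the scatter, which shows that no sizeable effect appeared on either one, but with only two pairs, and with the change sitting on a different ring in each, it does not show that the cores respond alike, and the opposite directions of the two steps cannot be read as a real difference.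

The pairs shown carry only pyridin-3-yl or pyridin-4-yl at the place of change, so they leave open what an amine, a carboxylic acid or a longer chain on that aromatic carbon would give in this assay. They also leave open whether the change would stay this small on a further core, or at any concentration other than the single one tested.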